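This account rests on a few compounds, and the source may have more. Where it says the series, first, only, none or still open, it means among the compounds named here.

Measured so far in a functional assay on K562 cells (Homo sapiens), read by MTT assay, with a stated time of 72 h; on this read-out lower numbers stand for stronger inhibition and higher numbers for weaker inhibition:

Compound 1 `Cc1ncnc2c1c(-c1cccs1)cn2[C@@H]1O[C@H](CO)[C@@H](O)[C@H]1O`: > 20000 nM, a limit of the assay, not a number.
Compound 2 `COc1ncnc2c1c(-c1cccs1)cn2[C@@H]1O[C@H](CO)[C@@H](O)[C@H]1O`: 6200 nM.
Compound 3 `CNc1ncnc2c1c(-c1cccs1)cn2[C@@H]1O[C@H](CO)[C@@H](O)[C@H]1O`: > 20000 nM, again a limit of the assay, not a number.

Compound 1 thus stands only at a limit on this read-out; the limit of > 20000 nM in this assay, at which 2 of the 3 values shown sit, marks where it sits, and compound 3 sits there as well. The one readable move within the three is an at least 3.2-fold lower number from compound 1 to compound 2 (0.50 log units; beyond the scatter), mirrored by an at least 3.2-fold higher number from compound 2 to compound 3 (0.50 log units; beyond the scatter); the move a step that the two limits leave unreadable from compound 1 to compound 3 stays unreadable between two limits.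

Compound 4 `C#Cc1cn([C@@H]2O[C@H](CO)[C@@H](O)[C@H]2O)c2ncnc(C)c12` differs from compound 1 by ethynyl in place of thiophen-2-yl on an aromatic carbon. Among the compounds with values here, none of the measured steps touches this place: all three concern the group on the other aromatic carbon of the shared core, while the thiophen-2-yl group is kept in compound 1, compound 2 and compound 3 alike. Within the data shown here, there is therefore no measured step that bears on the change to compound 4, and no direction can be drawn from the data for this assay. With compound 1 itself at a limit, the expectation for compound 4 is a value near that same limit, with the step that the limit leaves unreadable from compound 1 to compound 4 expected to be small. Compound 4 is estimated at 25000 nM, within 5000 nM to 100000 nM, and a limit rather than a number is the likelier outcome.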

Compound 4, half-maximal inhibitory concentration: 110 nM
Compound 4: middle estimate off by 230-fold (2.36 log units), on the high side, and the stated range ends above it.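

In this assay, within the data shown here, the earlier compounds kept thiophen-2-yl throughout and varied another group, so they showed nothing about this place, two ring bonds from the ring nitrogen; replacing thiophen-2-yl with ethynyl here gives an at least 180-fold lower number from compound 1 to compound 4 (2.25 log units; beyond the scatter), a large step that shows activity is strongly sensitive to the group at this place. Compound 1 stands at > 20000 nM, which is a limit of the assay and not a number, so the step has a lower bound but no fixed size. Nothing at hand gives a cause for this step.

Still open, from the compounds shown here alone, is whether ethynyl gives a similar step when the group that differs among compound 1, compound 2 and compound 3 is methoxy or methylamino rather than methyl. The compounds shown also leave open whether the gain follows from the triple bond or from the loss of the thiophen-2-yl ring, a question that groups such as nitrile, propynyl, ethyl or vinyl at the same place could help to separate.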